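Adding a bromo group to the benzyl arm of compound 2

The source may report more compounds than this note shows. Statements on the series, on what has been measured and on what is new or still open speak of the compounds shown alone.

In an ADME assay on Vero cells (Chlorocebus sabaeus) for cytotoxicity, read by resazurin assay, with a stated time of 72 h (a higher number here means that more compound is tolerated, a lower number that less compound is tolerated), compound 1 `CCCCN1C(=O)/C(=C\C(=O)C[C@@H]2O[C@H](COC(C)=O)[C@@H](OC(C)=O)[C@H](OC(C)=O)[C@H]2OC(C)=O)c2cc(Cl)ccc21` gives 88900 nM, and compound 2 `CC(=O)OC[C@H]1O[C@@H](CC(=O)/C=C2\C(=O)N(Cc3ccccc3)c3ccc(Cl)cc32)[C@H](OC(C)=O)[C@@H](OC(C)=O)[C@@H]1OC(C)=O` gives 91200 nM. Compound 2 holds the higher of the two numbers, but the gap is small: a 1.0-fold higher number from compound 1 to compound 2 (0.01 log units; within the scatter), so the two compounds cannot be told apart on this assay. Compound 3 `CC(=O)OC[C@H]1O[C@@H](CC(=O)/C=C2\C(=O)N(Cc3ccc(Br)cc3)c3ccc(Cl)cc32)[C@H](OC(C)=O)[C@@H](OC(C)=O)[C@@H]1OC(C)=O` has not yet been measured. It differs from compound 2 by bromo in place of hydrogen on an aromatic carbon; the same change, seen one bond further out, reads phenyl to 4-bromophenyl, or benzyl to 4-bromobenzyl. For the measured compounds named here, only one measured step exists here, the exchange of propyl for phenyl on the nitrogen-bound carbon of the ring, and it stayed within the scatter. That step touches the same arm of the molecule but not a substituent on the aromatic ring, so it gives little direct guidance on a bromo group. With a change that small and no sign so far that this arm moves tolerated concentration, compound 3 is expected to stay near compound 2, with a 1.1-fold lower number from compound 2 to compound 3 (0.03 log units; within the scatter) as the estimated step. The estimated value for compound 3 is 85000 nM, within a range from 40000 nM to 180000 nM.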

Compound 3, half-maximal cytotoxic concentration: 93300 nM
Beside the measured number, compound 3's estimate is 1.1-fold (0.04 log units) below it, and the stated range covers the measured number.
By their numbers in this assay, from the lowest: compounds 1, 2 and 3 (each within the scatter of the next).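

In this assay, a bromo group on an aromatic carbon of the benzyl arm, para to a large group, gives a 1.0-fold higher number from compound 2 to compound 3 (0.01 log units; within the scatter) and so leaves the reading unchanged within the scatter; the earlier step had exchanged the whole group on the chain carbon, whereas this one tests a substituent on the aromatic ring itself, adding a single heavy atom. The wider exchange reads the same way, with a 1.0-fold higher number from compound 1 to compound 3 (0.02 log units; within the scatter) showing that propyl and 4-bromophenyl on this carbon cannot be told apart here, so across these three compounds the arm on the amide-type nitrogen shows no effect on the concentration tolerated by the cells. No supporting data are available to explain this flat reading.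

The compounds shown leave open whether a group of a different kind on this aromatic carbon, such as an amine or a carboxylic acid, would also stay within the scatter. They also leave open whether the reading would hold if the acetyl groups, shared by all three compounds, gave way to free hydroxyl groups.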